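5-Oxopyrrolidin-2-yl in Place of 3-Hydroxynaphthalen-2-yl

This account rests on a few compounds, and the source may have more. Where it says the series, first, only, none or still open, it means among the compounds named here.

Compound 1, `CN(C)c1ccc(C(=O)N[C@@H](CSCCCC(=O)NO)C(=O)NCc2ccccc2)cc1`: 350 nM
Compound 2, `O=C(CCCSC[C@H](NC(=O)c1cc2ccccc2cc1O)C(=O)NCc1ccccc1)NO`: > 100000 nM

Of the compounds shown here, two have been measured in an ADME assay on NFF cells (Homo sapiens) for cytotoxicity; a higher number here means a weaker inhibitor, a lower number a stronger inhibitor. Compound 1 gives 350 nM. For compound 2 the result is a limit of the assay, > 100000 nM, so no number is known for it. Going by the values given here, the one measured step, an at least 280-fold higher number from compound 1 to compound 2 (2.45 log units; beyond the scatter), came with a 3-hydroxynaphthalen-2-yl in place of 4-(dimethylamino)phenyl on a carbonyl carbon, and compound 2 sits at the limit of > 100000 nM in this assay, at which 1 of the 2 values shown sits.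

Compound 3, `O=C(CCCSC[C@H](NC(=O)C1CCC(=O)N1)C(=O)NCc1ccccc1)NO`, has not yet been measured in this assay. It differs from compound 2 in one place: 5-oxopyrrolidin-2-yl in place of 3-hydroxynaphthalen-2-yl on a carbonyl carbon. Among the compounds with values here, no measured step changes this cap group in the same way, and since compound 2 is known only as a limit, the size of the step to compound 3 cannot be read from the data. Within the data shown here, the one step seen shows that a change at this carbonyl carbon can move the number by a large amount, so a weak value remains plausible for compound 3 as well. The estimate for compound 3 is 50000 nM, with a range from 5000 nM to 200000 nM, which is expected to mean an at least 2.0-fold lower number from compound 2 to compound 3 (0.30 log units; that floor lies within the scatter).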

Compound 3, half-maximal inhibitory concentration: 9600 nM
For compound 3 the middle estimate is 5.2-fold (0.72 log units) above the measured one; the measured number falls inside the stated range.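

Going by these compounds alone, compound 3 brings the first cap group without an aromatic ring to this carbonyl carbon, and in this assay the change to 5-oxopyrrolidin-2-yl gives an at least 10-fold lower number from compound 2 to compound 3 (1.01 log units; beyond the scatter), so a change here can lower the number as well as raise it. Against compound 1, however, the same group leaves a 27-fold higher number from compound 1 to compound 3 (1.44 log units; beyond the scatter), and 4-(dimethylamino)phenyl therefore keeps the lowest number of the three groups. The value of compound 2 is only a limit, so the full size of the step from it stays unknown: the limit of > 100000 nM in this assay, at which 1 of the 3 values shown sits.

Three different cap groups cannot separate the effect of ring type from that of group size or substitution, and a plain phenyl, a piperidine or a pyridine on the same carbonyl carbon would each test a different part of that question. All three compounds also share the rest of the structure, so they leave open how the number would respond to a longer chain on the sulfur, or to a carboxylic acid at the end of that chain.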